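The source may hold more compounds than are shown below. What is called first, only, known or untested is meant among the compounds shown, and "the series" means these compounds.

Of the compounds shown here, three built on a shared core have been measured in a functional assay on HeLa cells (Homo sapiens) for inhibition; on this read-out lower numbers stand for stronger inhibition and higher numbers for weaker inhibition. Compound 1 `Oc1cccc(-c2cc(-c3ccccc3F)cc(-c3cccc(O)c3)n2)c1` gives 16000 nM in this assay. Compound 2 `Oc1cccc(-c2cc(-c3ccc(F)cc3)cc(-c3cccc(O)c3)n2)c1` gives 1280 nM in this assay, and compound 3 `Oc1ccc(-c2cc(-c3ccc(F)cc3)cc(-c3cccc(O)c3)n2)cc1` gives 8080 nM in this assay. Compound 2 therefore stands lowest of the three numbers: the step of a 13-fold lower number from compound 1 to compound 2 (1.10 log units; beyond the scatter) is large, and the step of a 6.3-fold higher number from compound 2 to compound 3 (0.80 log units; beyond the scatter) is modest. The unmeasured compound 4 `Oc1cccc(-c2cc(-c3ccccc3C(F)(F)F)cc(-c3cccc(O)c3)n2)c1` differs from compound 2 in one place: 2-(trifluoromethyl)phenyl in place of 4-fluorophenyl on an aromatic carbon. Within the data shown here, only the step from compound 1 to compound 2 bears on this change, because a 13-fold lower number from compound 1 to compound 2 (1.10 log units; beyond the scatter) likewise exchanged a phenyl substituted in the 2 position for 4-fluorophenyl; the step from compound 2 to compound 3 concerns the hydroxyphenyl groups and does not. Compound 4 runs that exchange backwards, so a higher number in this assay is expected, with a step of roughly a 9.4-fold higher number from compound 2 to compound 4 (0.97 log units; beyond the scatter). Compound 4 is thus estimated at 12000 nM, within a range from 3000 nM to 48000 nM.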

Compound 4, half-maximal inhibitory concentration: 15200 nM
Beside the measured number, compound 4's estimate is 1.3-fold (0.10 log units) below it; measured number inside the range.
By their numbers in this assay, from the lowest: compound 2; then compounds 3, 4 and 1 (each within the scatter of the next).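

In this assay, the step of a 12-fold higher number from compound 2 to compound 4 (1.07 log units; beyond the scatter) shows that the low number of compound 2 is also lost with 2-(trifluoromethyl)phenyl at this position, opposite the ring nitrogen, so the earlier loss is not confined to 2-fluorophenyl. The step of a 1.1-fold lower number from compound 1 to compound 4 (0.02 log units; within the scatter) lies within the scatter, so in these two compounds trifluoromethyl and fluoro on that phenyl ring cannot be told apart. No measurement shown here accounts for this behaviour.

The compounds shown leave open whether 4-(trifluoromethyl)phenyl would keep a number like that of compound 2, which would help separate the effect of where the substituent sits from that of which substituent it is. They also leave open how a phenyl ring carrying an amine or a carboxylic acid would read at this position.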